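A Vinyl Group Added to a Level Series

This account rests on a few compounds, and the source may have more. Where it says the series, first, only, none or still open, it means among the compounds named here.

Of the compounds shown here, three have so far been measured in a functional assay on MCF7 cells (Homo sapiens) for inhibition, read by colorimetric assay and MTT assay, with a stated time of 72 h (a higher number here means a weaker inhibitor, a lower number a stronger inhibitor), and their values lie close together. Compound 1 `Cn1c2cnc1OCCCCCCCCOc1ccc(F)cc1-2` gives 52000 nM in this test, compound 2 `C=CCCCCCOc1ncc(-c2ccccc2OCCCCC=C)n1C` gives 63000 nM in the same test, and compound 3 `CCCCOc1ncc(-c2ccccc2OC)n1C` gives 55000 nM as its reading. Compound 3 stands among the other two, with both gaps inside the scatter, so these numbers support no ranking.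

Compound 4 `C=CCCCCOc1ncc(-c2ccccc2OC)n1C` has not yet been measured. It differs from compound 3 at one place, summarised as vinyl in place of hydrogen on a saturated chain carbon, four bonds along the chain from an oxygen on an aromatic ring in the count of the change. A vinyl group takes the place of a hydrogen on a saturated chain carbon, four bonds along the chain from an oxygen on an aromatic ring.

For the measured compounds named here, no measured pair isolates this change. Compound 2 also carries double bonds outside aromatic rings, and at 63000 nM it lies within the scatter of compound 3 at 55000 nM in this assay as the nearest available guide. Compound 2 differs from compound 3 in more than this one feature, so the comparison is only loose. No step beyond the scatter is expected, and no direction is favoured. The estimate for compound 4 is 55000 nM with an expected range from 30000 nM to 100000 nM for its reading.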

Compound 4, half-maximal inhibitory concentration: 5000 nM
Compound 4: the middle estimate sits 11-fold (1.04 log units) above what was measured; measured number outside the range, below it.
By their numbers in this assay, from the lowest: compound 4; then compounds 1, 3 and 2 (each within the scatter of the next).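

In this assay, for the compounds shown here, vinyl in place of hydrogen on a saturated chain carbon, four bonds along the chain from an oxygen on an aromatic ring, brings an 11-fold lower number from compound 3 to compound 4 (1.04 log units; beyond the scatter), the first step beyond the scatter in this small set. The position is therefore sensitive to change in this assay, even though the entering group has only 2 heavy atoms (2 carbon), no ring, 1 double bond outside aromatic rings, no hydrogen-bond donors or acceptors and no net charge. No measurement available here accounts for the size of this step, which rests on this single pair of compounds.

The compounds shown do not separate the double bond from the added chain length, so a longer saturated chain without a double bond would be needed to tell whether the step belongs to the vinyl group itself. They also leave open how this position would respond to an amine or a carboxylic acid in place of the vinyl group, and whether the step would carry over to another core.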